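This account rests on a few compounds, and the source may have more. Where it says the series, first, only, none or still open, it means among the compounds named here.

Measured so far:
compound 1 `CN(c1ccccc1CCCn1nnnc1[C@@H](COCc1ccccc1)NC(=O)C(C)(C)N)S(C)(=O)=O` with 1720 nM
compound 2 `CC(C)(N)C(=O)N[C@H](COCc1ccccc1)c1nnnn1CCCCC#N` with 3120 nM

For the measured compounds named here, in an assay on isolated protein for displacement of a labelled ligand from growth hormone secretagogue receptor type 1 (Homo sapiens), with a stated time of 1 h (on this read-out lower numbers stand for stronger inhibition and higher numbers for weaker inhibition), compound 2 holds the higher of the two numbers, with compound 1 as its only neighbour at a 1.8-fold higher number from compound 1 to compound 2 (0.26 log units; within the scatter). Compound 3 `CC(C)(N)C(=O)N[C@H](COCc1ccccc1)c1nnnn1CCC(=O)NCc1ccccc1` differs from compound 2 by benzylcarbamoyl in place of 2-cyanoethyl on a saturated chain carbon, two bonds along the chain from an aromatic nitrogen. Going by the values given here, only that one measured step speaks to a change at this end of the chain, and it stayed within the scatter even though compound 1 also carries an aromatic ring there. Compound 3 is therefore expected to move by no more than a 1.6-fold lower number from compound 2 to compound 3 (0.19 log units; within the scatter), and its value is estimated at 2000 nM, between 700 nM and 6000 nM.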

Compound 3, inhibition constant: 1070 nM
The estimate for compound 3 lay 1.9-fold (0.27 log units) above the measured number, within the range that was stated.
By their numbers in this assay, from the lowest: compounds 3, 1 and 2 (each within the scatter of the next, the first and the last beyond it).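

In this assay, benzylcarbamoyl in place of 2-cyanoethyl gives a 2.9-fold lower number from compound 2 to compound 3 (0.46 log units; beyond the scatter) and so shows that this end of the chain, whose earlier step stayed within the scatter, can move the number beyond it. The change brings in an aromatic ring and a hydrogen-bond donor together, and this single step cannot separate the two. No measurement at hand accounts for the shift. From the compounds shown here alone, whether a simple methyl amide would hold the gain without the ring stays open, as does the effect of a carboxylic acid or an amine at this place.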